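A few compounds are considered here, and "the series" means these few. Any claim that something is new, unique, unknown or untested is made for them only; others in the source may bear on it.

In a functional assay on A-375 cells (Homo sapiens) for cytotoxicity, read by MTT assay, with a stated time of 72 h, tested at 10 uM (a higher number here means more inhibition of growth at the concentration tested, a lower number less inhibition of growth), compound 1 `N/C(=N\NC(=S)N1CCOCC1)c1ccccn1` gives 18.3%. Compound 2 `N/C(=N\NC(=S)N1CCSCC1)c1ccccn1` gives 83.9%, and compound 3 `N/C(=N\NC(=S)N1CCCCC1)c1ccccn1` gives 85.8%. On these numbers compound 3 stands highest of the three: its gap to compound 2 is small, a number 1.9 percentage points higher from compound 2 to compound 3 (within the scatter), while its gap to compound 1 is large, a number 67.5 percentage points higher from compound 1 to compound 3 (beyond the scatter). The two large steps, a number 65.6 percentage points higher from compound 1 to compound 2 (beyond the scatter) and a number 67.5 percentage points higher from compound 1 to compound 3 (beyond the scatter), both come from exchanging the saturated ring that sits on the thiocarbonyl carbon.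

Compound 4 `Cc1cccc(/C(N)=N/NC(=S)N2CCCCC2)n1` differs from compound 3 at another place: methyl in place of hydrogen on an aromatic carbon. Within the data shown here, none of the three measured steps touches the aromatic ring; each of them alters only the ring on the thiocarbonyl carbon, so no measured step bears directly on this change, and these data give no guide to how a methyl group in this place behaves. In that situation the plain expectation is that the number stays close to that of compound 3, with an expected step of a number 5.8 percentage points lower from compound 3 to compound 4 (within the scatter) that lies within the scatter, though the range must be kept wide. Compound 4 is therefore estimated at 80%, with a likely range from 55% to 95%.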

Compound 4, percent growth inhibition at one concentration: 76.4%
For compound 4 the middle estimate is 3.6 percentage points above the measured one; the range from low to high includes it.
By their numbers in this assay, from the lowest: compound 1; then compounds 4, 2 and 3 (each within the scatter of the next).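

Among these compounds, the step on the aromatic ring, a number 9.4 percentage points lower from compound 3 to compound 4 (within the scatter), is the first measured change away from the saturated ring on the thiocarbonyl carbon. It shows that in this assay a methyl group can take the place of hydrogen at this position, next to the ring nitrogen, without a difference that can be told apart from the usual scatter, so a single added carbon here does not produce a large step like those seen on exchanging the saturated ring. Nothing available explains why the reading holds at this position, and the result stands only as an observation.

The compounds shown leave open whether this position would tolerate more than one carbon, such as an ethyl or a longer chain, or a group of a different kind, such as an amine, a methoxy group or a carboxylic acid. They also leave open whether a methyl group would behave the same way elsewhere on the aromatic ring, or on the compounds carrying the morpholin-4-yl or thiomorpholin-4-yl ring.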